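The source may report more compounds than this note shows. Statements on the series, on what has been measured and on what is new or still open speak of the compounds shown alone.

Measured so far:
compound 1 `NCc1ccc(-c2nc3cc(C(=O)NCCC(=O)O)ccc3[nH]2)cc1` — 100000 nM
compound 2 `NCc1ccc(Cn2cnc3cc(C(=O)NCCC(=O)O)ccc32)cc1` — 83000 nM
compound 3 `Cc1ccc(S(=O)(=O)N[C@@H](CNC(=O)c2ccc3oc(-c4ccc(C(=N)N)cc4)nc3c2)C(=O)O)cc1` — 10 nM

All three numbers come from a functional assay (plasma) for inhibition, with Homo sapiens as the target; a higher number here means a weaker inhibitor, a lower number a stronger inhibitor. Compound 1 and compound 2 sit at the weak end of the series; in this assay compound 1 gives 100000 nM and compound 2 gives 83000 nM, both far from the third compound. Compound 3 holds the lowest number of the three, with 10 nM in this assay, and its gap to each of the other two compounds lies well beyond the scatter, so it is the strongest inhibitor among those measured.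

The next compound, compound 4 `CCCCOC(=O)N[C@@H](CNC(=O)c1ccc2oc(-c3ccc(C(=N)N)cc3)nc2c1)C(=O)O`, keeps the whole of compound 3 apart from one change:
butoxycarbonyl in place of (4-methylphenyl)sulfonyl on an amine nitrogen
Among the compounds with values here, no measured pair shows a step of this kind, so there is no directly comparable number to lean on. The carboxylic acid, the amide link and the amidine-bearing part of compound 3 are all kept, and the exchange is confined to the group on the amine nitrogen. The expectation is a modest step from compound 3 to compound 4 of a 2.5-fold higher number from compound 3 to compound 4 (0.40 log units; beyond the scatter) in this assay, a small loss at most, possibly none beyond the scatter. Compound 4 is therefore expected to give about 25 nM in this assay, within a range of 5 nM to 120 nM.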

Compound 4, half-maximal inhibitory concentration: 20 nM
Estimate against measurement, compound 4: 1.3-fold (0.10 log units) above, and the stated range covers the measured number.
By their numbers in this assay, from the lowest: compounds 3 and 4 (each within the scatter of the next); then compounds 2 and 1 (each within the scatter of the next).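

Compound 4 gives the series its first readable step: in this assay, butoxycarbonyl in place of (4-methylphenyl)sulfonyl on this amine nitrogen gives a 2.0-fold higher number from compound 3 to compound 4 (0.30 log units; within the scatter) and so leaves the two compounds indistinguishable. For this pair, the nitrogen carries either a sulfonyl group with a six-membered aromatic ring or a ringless butoxycarbonyl group with no separation in the read-out, so neither the sulfur nor the aromatic ring of the group that leaves is required for a number at this level. No measurement on hand bears on why the two compounds read alike.

Still open, as far as these compounds go, is whether a smaller group such as acetyl, or a free amine on this nitrogen, would keep the number in this assay. Also open, from the compounds shown here alone, is whether a benzyloxycarbonyl group would do the same.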